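Compound 4: a smaller group on the shared core

The compounds below may be only part of what the source reports. "The series", "measured", "known", "first", "only" and "open" are said of these compounds alone.

Values measured in an ADME assay on microsomes from liver (Homo sapiens) for metabolic stability; on this read-out lower numbers stand for slow clearance and higher numbers for fast clearance:
- compound 1 `CC(=O)N[C@@H]1CCC[C@H](C(=O)Nc2cc(-c3cnn4c3CCCC4)c(Cl)cn2)C1`: 17 mL.min-1.g-1
- compound 2 `CC(=O)N[C@@H]1CCC[C@H](C(=O)Nc2cc(-c3cnn(C)c3C)c(Cl)cn2)C1`: 3.3 mL.min-1.g-1
- compound 3 `CC(=O)N[C@@H]1CCC[C@H](C(=O)Nc2cc(-c3cnc4n3CCCC4)c(Cl)cn2)C1`: 16 mL.min-1.g-1

Compound 3, at 16 mL.min-1.g-1, stands at the high end of these three numbers, together with compound 1. The step between those two is a 1.1-fold lower number from compound 1 to compound 3 (0.03 log units; within the scatter). Compound 2 lies well away from both.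

Compound 4 `CC(=O)N[C@@H]1CCC[C@H](C(=O)Nc2cc(-c3cnn4c3CCC4)c(Cl)cn2)C1` has not yet been measured. Its structure has a group of 8 heavy atoms (6 carbon, 2 nitrogen; one five-membered non-aromatic ring with 1 hetero atom, one five-membered aromatic ring with 2 hetero atoms) in place of a group of 9 heavy atoms (7 carbon, 2 nitrogen; one five-membered aromatic ring with 2 hetero atoms, one six-membered non-aromatic ring with 1 hetero atom), on an aromatic carbon. The change sits on an aromatic carbon of a six-membered aromatic ring, ortho to a chloro group and opposite the ring nitrogen.

Within the data shown here, no measured compound carries this group, so the data offer only a bracket. Two steps frame it, a 5.2-fold lower number from compound 1 to compound 2 (0.71 log units; beyond the scatter) and a 4.8-fold higher number from compound 2 to compound 3 (0.69 log units; beyond the scatter), and both are modest. Each links a group of 9 heavy atoms with the group of 7 heavy atoms in compound 2. The group of 8 heavy atoms falls between these by count, so a partial move towards compound 2 seems reasonable, though three compounds make a thin basis. The expected change is a 1.9-fold lower number from compound 3 to compound 4 (0.27 log units; within the scatter), a lower number but a smaller step than the two above. For compound 4 the estimated value is 8.5 mL.min-1.g-1, with an expected range of 4 mL.min-1.g-1 to 17 mL.min-1.g-1.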

Compound 4, intrinsic clearance in microsomes: < 3 mL.min-1.g-1
Compound 4: only a limit was reported (the forecaster's own chance of this, stated with the estimate: 3%); middle value at least 2.8-fold (0.45 log units) from the limit.
By their numbers in this assay, from the lowest: compound 2; then compounds 3 and 1 (each within the scatter of the next). At a limit, below all of these: compound 4.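

Compound 4 gives < 3 mL.min-1.g-1 in this assay, and this is a limit of the assay, not a number: the limit of < 3 mL.min-1.g-1 in this assay, at which 1 of the 4 values shown sits.

On the aromatic carbon opposite the ring nitrogen, a five-membered non-aromatic ring in place of a six-membered one is enough to give an at least 5.3-fold lower number from compound 3 to compound 4 (0.72 log units; beyond the scatter) and an at least 5.6-fold lower number from compound 1 to compound 4 (0.75 log units; beyond the scatter), whereas the two groups carrying the six-membered non-aromatic ring stay level, with a 1.1-fold lower number from compound 1 to compound 3 (0.03 log units; within the scatter). The remaining comparison, an at least 1.1-fold lower number from compound 2 to compound 4 (0.04 log units; that floor lies within the scatter), sets no order between those two compounds, but it places the group of 8 heavy atoms at the low end with the group of 7 heavy atoms, not part-way towards the groups of 9 heavy atoms, so heavy-atom count alone does not track this read-out across the four compounds.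

On these data alone, how far compound 4 lies beneath its limit stays unknown, and with it whether compound 4 truly differs from compound 2. Also open, as far as these compounds go, is whether the low clearance would survive a hydroxyl or a fluoro group on the five-membered non-aromatic ring, or an ether oxygen within it.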